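The compounds below may be only part of what the source reports. "The series", "measured", "known", "first", "only" and "open" are said of these compounds alone.

Of the compounds shown here, two built on one shared core have been measured in a physicochemical assay for lipophilicity, measured as octanol-water partition; a higher number here means a more lipophilic compound, a lower number a more polar compound. Compound 1 `O=C(NNc1ccnc2cc(Cl)ccc12)c1ccccc1/N=C/c1ccc(F)cc1`, carrying 4-fluorophenyl, gives 5.18. Compound 2 `O=C(NNc1ccnc2cc(Cl)ccc12)c1ccccc1/N=C/c1ccc(Cl)cc1Cl`, carrying 2,4-dichlorophenyl, gives 6.22, the higher of the two numbers, and its gap to compound 1 lies beyond the scatter. Compound 3 `O=C(NNc1ccnc2cc(Cl)ccc12)c1ccccc1/N=C/c1ccc(Br)cc1` alters the same place, and the change is 4-bromophenyl in place of 2,4-dichlorophenyl on a carbon with a double bond to nitrogen. Within the data shown here, only one measured step bears on this exchange, and it is large: a number 1.04 log units higher from compound 1 to compound 2 (beyond the scatter), with 2,4-dichlorophenyl in place of 4-fluorophenyl on that same carbon with a double bond to nitrogen. Among the measured compounds shown here, no measured compound yet carries 4-bromophenyl, so the expectation is loose: a downward step in this assay, smaller than that one, leaving compound 3 between the two measured compounds. The expected change is a number 0.37 log units lower from compound 2 to compound 3 (beyond the scatter). For compound 3 the estimated value is 5.85, with an expected range from 5.5 to 6.2.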

Compound 3, partition coefficient: 5.76
The estimate for compound 3 lay 0.09 log units above the measured number, within the range that was stated.
By their numbers in this assay, from the lowest: compound 1; then compound 3; then compound 2.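

With this assay, this position on the carbon with a double bond to nitrogen now shows a response to a single halogen exchange: bromo in place of fluoro on an aromatic carbon gives a number 0.58 log units higher from compound 1 to compound 3 (beyond the scatter), so the rise at this position does not depend on the 2,4-dichlorophenyl group alone. Yet 4-bromophenyl does not match that group, since the exchange gives a number 0.46 log units lower from compound 2 to compound 3 (beyond the scatter), and the three groups therefore stand apart at this position. Nothing available explains these differences.

Open, going by these compounds, is how 4-chlorophenyl would fall in this assay, which would separate the kind of halogen from the number of halogens on the ring. Also open, on these data alone, is where a phenyl ring carrying an amine or a carboxylic acid would stand in relation to compound 1.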